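The compounds below may be only part of what the source reports. "The series", "measured", "known", "first", "only" and "open" are said of these compounds alone.

Measured so far:
- compound 1, `O=C(COc1cccc2ccccc12)N/N=C/c1ccc(Cl)cc1`: 100 ug/mL
- compound 2, `COc1cc(/C=N/NC(=O)COc2cccc3ccccc23)cc(OC)c1O`: 100 ug/mL

Both were tested in an ADME assay on HEL cells (Homo sapiens) for cytotoxicity; a lower number here means that less compound is tolerated, a higher number that more compound is tolerated. In this assay compound 1 gives 100 ug/mL, and compound 2 gives 100 ug/mL. Compound 1 therefore stands level with compound 2 at the digits shown; the two values sit within the scatter of each other, so no order between them can be read from these numbers.

Compound 3, `O=C(COc1cccc2ccccc12)N/N=C/c1ccccc1Cl`, has not yet been measured in this assay. It differs from compound 1 by 2-chlorophenyl in place of 4-chlorophenyl on a carbon with a double bond to nitrogen. Among the compounds with values here, no step between measured compounds exists here to show how such a change moves the read-out, so the expectation rests on the similar values of the two measured compounds alone. For compound 3 the step from compound 1 is expected to be no change at the digits printed from compound 1 to compound 3 (within the scatter), that is, none beyond the scatter. Compound 3 is therefore expected to give about 100 ug/mL, within a range from 50 ug/mL to 200 ug/mL.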

Compound 3, minimum cytotoxic concentration: 100 ug/mL
Compound 3: middle estimate and measured number agree at the digits printed, within the range that was stated.
By their numbers in this assay, from the lowest: compounds 1, 2 and 3 (each within the scatter of the next).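

In this assay, putting 2-chlorophenyl in place of 4-chlorophenyl on a carbon with a double bond to nitrogen gives no change at the digits printed from compound 1 to compound 3 (within the scatter). Within the data shown here, the earlier compounds offered no measured step at all, so this is the first direct evidence at this position: for these two chlorophenyl groups, which have the same atoms joined differently, this read-out shows no difference. No measurement at hand accounts for this result.

The compounds shown leave open whether a different kind of group on the phenyl ring, such as an amine or a carboxylic acid, would move the read-out away from this level. They also leave open what a change elsewhere on the shared core, such as a longer chain, would do to it.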